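A few compounds are considered here, and "the series" means these few. Any claim that something is new, unique, unknown or untested is made for them only; others in the source may bear on it.

Measured in a functional assay on DU-145 cells (Homo sapiens) for inhibition, read by trypan blue exclusion, with a stated time of 96 h; a lower number here means a stronger inhibitor of growth, a higher number a weaker inhibitor of growth:
- compound 1 `Cc1ccc(CS(=O)(=O)/C(=C/c2cc(C)cc(C)c2)C(=O)c2ccc(Cl)cc2)cc1`: 10000 nM
- compound 2 `Cc1ccc(CS(=O)(=O)/C(=C/c2cccc(Cl)c2Cl)C(=O)c2ccc(Cl)cc2)cc1`: 1000 nM
- compound 3 `CCOc1ccc(/C=C(\C(=O)c2ccc(Cl)cc2)S(=O)(=O)Cc2ccc(C)cc2)cc1OC`: 10000 nM

Compound 1, at 10000 nM, stands level with compound 3, and together they give the highest number of the three. The next compound, compound 4 `Cc1cc(C)cc(/C=C(\C(=O)c2ccc(Cl)cc2)S(=O)(=O)c2ccc(Br)cc2)c1`, has not yet been measured. It carries 4-bromophenyl in place of 4-methylbenzyl on a sulfonyl sulfur.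

Within the data shown here, none of the measured steps touches this position. All of them exchange the aryl group on the double-bonded chain carbon instead. They show a 10-fold lower number from compound 1 to compound 2 (1.00 log units; beyond the scatter), a modest step beyond the scatter, and no change at the digits printed from compound 1 to compound 3 (within the scatter), which lies within it. These steps give only a rough idea of how far one exchange can move the number in this small set, and they offer no direction for the change at the sulfonyl sulfur. No step beyond the scatter is therefore expected in this assay, although the uncertainty is wide. The expected step is a 1.3-fold lower number from compound 1 to compound 4 (0.10 log units; within the scatter). For compound 4 the estimated value is 8000 nM, with an expected range from 1500 nM to 30000 nM.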

Compound 4, concentration for 50% growth inhibition: 10000 nM
Beside the measured number, compound 4's estimate is 1.3-fold (0.10 log units) below it, within the range that was stated.
By their numbers in this assay, from the lowest: compound 2; then compounds 1, 3 and 4 (each within the scatter of the next).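

In this assay, putting 4-bromophenyl in place of 4-methylbenzyl on a sulfonyl sulfur gives no change at the digits printed from compound 1 to compound 4 (within the scatter). Among these compounds, this is the first reading at this position, as the earlier steps all exchanged the aryl group on the double-bonded chain carbon. With 3,5-dimethylphenyl kept on that carbon, the change at the sulfonyl sulfur thus leaves the number where it was, so this one exchange gives no sign that the group on the sulfur governs growth inhibition here, and no measurement available bears on why the two compounds read alike.

As far as these compounds go, whether the same exchange would read alike with the 2,3-dichlorophenyl group of compound 2 remains open. The compounds shown also leave open how an amine, a carboxylic acid or a longer chain on the sulfonyl sulfur would read.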